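The source may hold more compounds than are shown below. What is called first, only, known or untested is meant among the compounds shown, and "the series" means these compounds.

Of the compounds shown here, three sharing one core have been measured in a functional assay on HEK293 cells with D(4) dopamine receptor (Homo sapiens) as the target, read by FLIPR; on this read-out higher numbers stand for an effect only at larger amounts of compound and lower numbers for an effect already at smaller amounts. Compound 1 `CO/N=C(/CCN1CCN(c2ccccn2)CC1)c1ccccc1Cl` gives 57.2 nM. Compound 2 `CO/N=C(/CCN1CCN(c2ccccn2)CC1)c1ccc(Cl)cc1` gives 56.6 nM. Compound 3 `CO/N=C(/CCN1CCN(c2ccccn2)CC1)c1cc(C)cc(C)c1` gives 74.7 nM, the highest of the three numbers, though it sits within the usual scatter of both others. Each of these compounds carries a different aryl group on the carbon with a double bond to nitrogen, and the exchanges among them were all small: a 1.0-fold lower number from compound 1 to compound 2 (0.00 log units; within the scatter), a 1.3-fold higher number from compound 1 to compound 3 (0.12 log units; within the scatter), and a 1.3-fold higher number from compound 2 to compound 3 (0.12 log units; within the scatter). Compound 4 `CO/N=C(/CCN1CCN(c2ccccn2)CC1)c1ccc(Cl)cc1Cl` has not yet been measured; it differs from compound 3 in one place: 2,4-dichlorophenyl in place of 3,5-dimethylphenyl on a carbon with a double bond to nitrogen. All three measured steps bear on this exchange, since each of them also swaps one aryl group for another at the same place, and none of them moved the number beyond the scatter. A further swap of this kind is therefore expected to leave the number essentially unchanged, so the expected step of a 1.1-fold lower number from compound 3 to compound 4 (0.06 log units; within the scatter) is small. For compound 4 in this assay the estimate is 65 nM, with a range from 30 nM to 150 nM.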

Compound 4, half-maximal effective concentration: 296 nM
For compound 4 the middle estimate is 4.6-fold (0.66 log units) below the measured one; measured number above the stated range.
By their numbers in this assay, from the lowest: compounds 2, 1 and 3 (each within the scatter of the next); then compound 4.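

Within the data shown here, until now, every aryl group on this carbon stayed within the scatter of the others, but in this assay the 2,4-dichlorophenyl group is the first to go beyond it, with a 4.0-fold higher number from compound 3 to compound 4 (0.60 log units; beyond the scatter) as the exchange. The two compounds with a single chloro locate the change more closely: adding a second chloro gives a 5.2-fold higher number from compound 2 to compound 4 (0.72 log units; beyond the scatter) and a 5.2-fold higher number from compound 1 to compound 4 (0.71 log units; beyond the scatter), while the two single-chloro compounds themselves sit within the scatter of each other, so among these compounds only the ring with both chloro groups stands apart. Nothing available here explains this rise.

From the compounds shown here alone, whether the rise depends on chloro itself remains open, and a fluoro or methoxy group in place of the added chloro would test that. Going by these compounds, it is also open how an amine or a carboxylic acid on this ring would behave.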